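Mouse liver microsome stability: piperazine variation on the core

The compounds below may be only part of what the source reports. "The series", "measured", "known", "first", "only" and "open" are said of these compounds alone.

Measured compounds:
compound 1, `CCN1CCN(c2cccc3c2C[C@H](CN(C)[C@H]2CCCc4cccnc42)NC3)CC1` — 18.8%
compound 2, `CN(C[C@H]1Cc2c(cccc2N2CCN3CCC[C@@H]3C2)CN1)[C@H]1CCCc2cccnc21` — 36.7%
compound 3, `CN1CCN(c2cccc3c2C[C@H](CN(C)[C@H]2CCCc4cccnc42)NC3)CC1` — 17%

In an ADME assay on microsomes from liver (Mus musculus) for metabolic stability, read by LC-MS, with a stated time of 10 min (a lower number here means that less of the compound is left, a higher number that more of the compound is left), compound 3 and compound 1 lie within the usual scatter of each other; the step of a number 1.8 percentage points lower from compound 1 to compound 3 (within the scatter) shows that removing the methyl on the ring amine nitrogen left the read-out essentially unchanged. Against compound 2 the gap is larger: a number 19.7 percentage points lower from compound 2 to compound 3 (beyond the scatter), and in the other direction a number 17.9 percentage points higher from compound 1 to compound 2 (beyond the scatter), both modest but beyond the scatter.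

Compound 4, `CN(C[C@H]1Cc2c(cccc2N2CCNC(C)(C)C2)CN1)[C@H]1CCCc2cccnc21`, has not been measured. Its change from compound 3 is 3,3-dimethylpiperazin-1-yl in place of 4-methylpiperazin-1-yl on an aromatic carbon. The step that bears most directly on it is the methyl change on the same ring amine, a number 1.8 percentage points lower from compound 1 to compound 3 (within the scatter), which stayed within the scatter. The bicyclic replacement behind a number 17.9 percentage points higher from compound 1 to compound 2 (beyond the scatter) is a different kind of change and gives only a weak hint that altering this ring can move the number.

Compound 4 is therefore expected to give 22%, with a range of 10% to 38%. The expected step of a number 5 percentage points higher from compound 3 to compound 4 (within the scatter) is estimated to stay within, or only just beyond, the scatter.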

Compound 4, percent of the compound remaining: 44%
Beside the measured number, compound 4's estimate is 22 percentage points below it; the whole stated range lies below it.
By their numbers in this assay, from the lowest: compounds 3 and 1 (each within the scatter of the next); then compounds 2 and 4 (each within the scatter of the next).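

In this assay, the substitution pattern of the piperazine on this aromatic carbon proves able to move the read-out, which the methyl-to-ethyl comparison on the ring amine did not show: 3,3-dimethylpiperazin-1-yl gives a number 27 percentage points higher from compound 3 to compound 4 (beyond the scatter) against 4-methylpiperazin-1-yl and a number 25.2 percentage points higher from compound 1 to compound 4 (beyond the scatter) against 4-ethylpiperazin-1-yl. A single six-membered ring also suffices here, since a number 7.3 percentage points higher from compound 2 to compound 4 (within the scatter) leaves the two compounds unseparated, so the second ring of the group in compound 2 is not required for this level. The change is not a single one, however, as the entering group both places two methyl groups on the ring and carries a hydrogen-bond donor that the leaving group lacks.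

Nothing at hand gives a reason for the rise. As far as these compounds go, whether the gain follows the two methyl groups or the free ring amine stays open, and 3,3,4-trimethylpiperazin-1-yl or plain piperazin-1-yl would separate the two.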